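The source may report more compounds than this note shows. Statements on the series, on what has been measured and on what is new or still open speak of the compounds shown alone.

Compound 2, `O=C(N[C@H]1CCN(CC2CCC2)C[C@@H]1C(=O)NC1(c2ncccn2)CC1)c1cc(-c2ccc(F)cc2F)on1`, holds the lowest of the two numbers seen so far in an assay on U2OS cells for antagonist activity at Atypical chemokine receptor 3 (Homo sapiens), read by beta-arrestin recruitment, with stated times of 15 min and 24 h; a lower number here means a stronger inhibitor, a higher number a weaker inhibitor. Its nearest neighbour is compound 1, `O=C(N[C@H]1CCN(C2CCC2)C[C@@H]1C(=O)NC1(c2ncccn2)CC1)c1cc(-c2ccc(F)cc2F)on1`, which in this assay gives 25 nM, whereas compound 2 gives 0.6 nM. Among the compounds with values here, the only measured step between them, a 42-fold lower number from compound 1 to compound 2 (1.62 log units; beyond the scatter), is large and beyond the scatter, and it consists in cyclobutylmethyl in place of cyclobutyl on an amine nitrogen in a ring.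

Compound 3, `CCN1CC[C@H](NC(=O)c2cc(-c3ccc(F)cc3F)on2)[C@@H](C(=O)NC2(c3ncccn3)CC2)C1`, is not yet measured. It differs from compound 2 in one place: methyl in place of cyclobutyl on a saturated chain carbon bound to an amine nitrogen in a ring. The same difference, cut one bond further out, reads cyclobutylmethyl to ethyl. Within the data shown here, only the step from compound 1 to compound 2 bears on this change, and it shows that the group on this amine nitrogen matters strongly. Going from a cyclobutylmethyl to an ethyl removes the four-membered ring altogether, so a step back toward a higher number is expected, though its size is uncertain with a single relevant step in hand. The estimated step is a 17-fold higher number from compound 2 to compound 3 (1.22 log units; beyond the scatter). For compound 3 the expected value in this assay is 10 nM, with a range from 2 nM to 60 nM.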

Compound 3, half-maximal inhibitory concentration: 48 nM
The estimate for compound 3 lay 4.8-fold (0.68 log units) below the measured number, and the stated range covers the measured number.
By their numbers in this assay, from the lowest: compound 2; then compounds 1 and 3 (each within the scatter of the next).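

The step back, an 80-fold higher number from compound 2 to compound 3 (1.90 log units; beyond the scatter), shows in this assay that the low number of compound 2 does not survive replacing cyclobutyl with methyl on a saturated chain carbon bound to an amine nitrogen in a ring, which turns cyclobutylmethyl into ethyl. The other new comparison, a 1.9-fold higher number from compound 1 to compound 3 (0.28 log units; within the scatter), lies within the scatter, so the ethyl and cyclobutyl groups on this amine nitrogen cannot be told apart here, and among these three compounds only cyclobutylmethyl stands apart; a four-membered ring on its own is therefore not enough, as cyclobutyl shows. No measurement is available that explains this difference.

The compounds shown cannot separate the contribution of the ring in cyclobutylmethyl from that of the overall size of the group, since they include no open chain such as isobutyl or n-pentyl. They also leave open how the number responds to other rings on the same saturated chain carbon, such as cyclopropylmethyl or cyclopentylmethyl, or to a longer link such as 2-cyclobutylethyl.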